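This account rests on a few compounds, and the source may have more. Where it says the series, first, only, none or still open, it means among the compounds named here.

Measured compounds:
- compound 1, `Cc1ccccc1Cn1cc(COc2ccc3c(=O)ccoc3c2)nn1`: 15300 nM
- compound 2, `CC(C)(C)c1ccc(Cn2cc(COc3ccc4c(=O)ccoc4c3)nn2)cc1`: 17600 nM
- compound 3, `C#CCOc1ccc2c(=O)ccoc2c1`: 64700 nM

Of the compounds shown here, three have been tested in a functional assay on HeLa cells (Homo sapiens) for cytotoxicity, read by MTT assay, with a stated time of 48 h; a higher number here means a weaker inhibitor, a lower number a stronger inhibitor. Compound 1 gives the lowest of the three numbers, but the nearest value, that of compound 2, lies within the scatter of the measurement, so the two cannot be told apart on these data. Compound 3 stands furthest from compound 1, with a higher number beyond the scatter.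

Compound 4, `O=c1ccoc2cc(OCc3cn(Cc4cccc([N+](=O)[O-])c4)nn3)ccc12`, has not yet been measured in this assay. It differs from compound 1 in one place: 3-nitrophenyl in place of 2-methylphenyl on a saturated chain carbon bound to an aromatic nitrogen. Going by the values given here, the two measured compounds that carry the same core with a differently substituted side chain give values within the scatter of each other, and no measured step speaks to this particular change. In this assay the expected step is a 1.0-fold higher number from compound 1 to compound 4 (0.02 log units; within the scatter), no larger than the scatter and in no clear direction. Compound 4 is therefore estimated at 16000 nM, with a range from 7000 nM to 36000 nM.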

Compound 4, half-maximal inhibitory concentration: 17300 nM
Compound 4: middle estimate off by 1.1-fold (0.03 log units), on the low side, and the stated range covers the measured number.
By their numbers in this assay, from the lowest: compounds 1, 4 and 2 (each within the scatter of the next); then compound 3.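

In this assay, going by these compounds alone, the change to 3-nitrophenyl in place of 2-methylphenyl, on a saturated chain carbon bound to an aromatic nitrogen, is the first single-place change that can be read, and it gives a 1.1-fold higher number from compound 1 to compound 4 (0.05 log units; within the scatter). At this position, then, a group of 9 heavy atoms with 2 hydrogen-bond acceptors replaces one of 7 heavy atoms with none, and the number stays within the scatter. Nothing available bears on this result.

The compounds shown leave open whether an amine or a carboxylic acid on the phenyl ring would shift the number beyond the scatter. They also leave open whether a plain alkyl chain in place of the substituted phenyl would do so.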